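A few compounds are considered here, and "the series" means these few. Any claim that something is new, unique, unknown or untested is made for them only; others in the source may bear on it.

Three compounds carry the shared core with an acrylamide arm. In a functional assay on Huh-7 cells (Homo sapiens) for inhibition, read by MTT assay, with a stated time of 48 h (on this read-out higher numbers stand for weaker inhibition and lower numbers for stronger inhibition), compound 1 `COc1ccc2c(=O)c(/C=C/C(=O)Nc3cccc(C)c3)coc2c1` gives 15500 nM. Compound 2 `O=C(/C=C/c1coc2cc(O)ccc2c1=O)NCc1ccccc1` gives 4690 nM in this assay. Compound 3 `COc1ccc2c(=O)c(/C=C/C(=O)NCc3ccccc3)coc2c1` gives 13600 nM in this assay, the second highest of the three numbers, with compound 1 within the scatter and compound 2 clearly lower. The step of a 1.1-fold lower number from compound 1 to compound 3 (0.06 log units; within the scatter) is the one that bears on the next change; the step of a 2.9-fold higher number from compound 2 to compound 3 (0.46 log units; beyond the scatter) concerns the phenol and does not. Compound 4 `COc1ccc2c(=O)c(/C=C/C(=O)Nc3cc(C)ccc3C)coc2c1` differs from compound 3 by 2,5-dimethylphenyl in place of benzyl on an amide-type nitrogen. Since an aryl on that nitrogen in compound 1 gave only a 1.1-fold lower number from compound 1 to compound 3 (0.06 log units; within the scatter), no step beyond the scatter is expected here. Compound 4 is expected at 14500 nM with a range from 6000 nM to 35000 nM. This amounts to an expected step of a 1.1-fold higher number from compound 3 to compound 4 (0.03 log units; within the scatter).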

Compound 4, half-maximal inhibitory concentration: 11100 nM
For compound 4 the middle estimate is 1.3-fold (0.12 log units) above the measured one, within the range that was stated.
By their numbers in this assay, from the lowest: compound 2; then compounds 4, 3 and 1 (each within the scatter of the next).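

In this assay, 2,5-dimethylphenyl and benzyl on the amide-type nitrogen are not told apart (a 1.2-fold lower number from compound 3 to compound 4 (0.09 log units; within the scatter)), so the aryl-versus-benzyl result of compound 1 and compound 3 extends to a second aryl group. A further methyl in place of hydrogen on an aromatic carbon also stays within the scatter (a 1.4-fold lower number from compound 1 to compound 4 (0.15 log units; within the scatter)). Nothing given here explains this flat response.

Open, going by these compounds, is whether an amine or a carboxylic acid on that aryl ring would give a step beyond the scatter. Also open, on these data alone, is whether the free hydroxyl of compound 2 keeps its lower number with an aryl on that nitrogen.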